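Replacing 2-fluorophenyl with 3,5-dichlorophenyl in compound 3

The compounds below may be only part of what the source reports. "The series", "measured", "known", "first", "only" and "open" are said of these compounds alone.

Of the compounds shown here, two have so far been tested in a functional assay on U-937 cells (Homo sapiens) for antiproliferative activity, read by MTT assay, with a stated time of 24 h (a lower number here means a stronger inhibitor of growth, a higher number a weaker inhibitor of growth), and neither has yielded a number. Compound 1 `Cc1ccc(NC(=O)c2ccccc2Sc2ccccc2C#N)cc1NC(=O)c1cnoc1C` gives > 30000 nM, which is a limit of the assay. Compound 2 `Cc1ccc(NC(=O)Nc2ccccc2F)cc1NC(=O)c1cnoc1C` gives > 30000 nM, which is likewise a limit. Among the compounds with values here, compound 2 therefore stands with compound 1 at the limit of > 30000 nM in this assay, at which 2 of the 2 values shown sit, and no measured step connects the two.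

Compound 3 `Cc1ccc(NC(=O)Nc2cc(Cl)cc(Cl)c2)cc1NC(=O)c1cnoc1C` keeps the rest of compound 2 and carries 3,5-dichlorophenyl in place of 2-fluorophenyl on an amide-type nitrogen in one change. Within the data shown here, no measured step shows what a change at this place does in this assay, so any forecast is loose. With compound 2 at > 30000 nM as the only reference, a small gain in growth inhibition is expected at best, and compound 3 may well show no change that the assay can detect. The expected shift an at least 1.5-fold lower number from compound 2 to compound 3 (0.17 log units; that floor lies within the scatter) is only a rough estimate. Compound 3 is estimated at 20000 nM, with an expected range from 5000 nM to 50000 nM in this measurement.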

Compound 3, concentration for 50% growth inhibition: > 30000 nM
Compound 3: no number, only a limit (the forecaster's own chance of this, stated with the estimate: 55%); middle value at least 1.5-fold (0.17 log units) away from the limit.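

In this assay compound 3 gives > 30000 nM, which is a limit of the assay. Compound 2 also stands at a limit, so no step can be read between compound 2 and compound 3. The compounds shown leave open whether any change to the shared core would yield a measurable value at all, as all of them sit at one limit: the limit of > 30000 nM in this assay, at which 3 of the 3 values shown sit.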